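The source may hold more compounds than are shown below. What is called first, only, known or untested is meant among the compounds shown, and "the series" means these compounds.

Of the compounds shown here, three sharing one core have been measured in a functional assay on HeLa cells (Homo sapiens) for antiproliferative activity, read by MTT assay, with a stated time of 72 h; on this read-out lower numbers stand for stronger inhibition and higher numbers for weaker inhibition. Compound 1 `COc1cc(C(=O)c2sc3ccccc3c2-c2ccccc2)cc(OC)c1OC` gives 1900 nM. Compound 2 `COc1cc(C(=O)c2sc3ccccc3c2-c2ccc(SC)cc2)cc(OC)c1OC`, which carries methylsulfanyl in place of hydrogen on an aromatic carbon, gives 3500 nM; the step is a 1.8-fold higher number from compound 1 to compound 2 (0.27 log units; within the scatter). Compound 3 `CCOc1ccc(-c2c(C(=O)c3cc(OC)c(OC)c(OC)c3)sc3ccccc23)cc1`, which carries ethoxy in place of hydrogen on an aromatic carbon, gives 3000 nM; the step is a 1.6-fold higher number from compound 1 to compound 3 (0.20 log units; within the scatter), and the step from the methylsulfanyl analogue is a 1.2-fold lower number from compound 2 to compound 3 (0.07 log units; within the scatter). Compound 3 thus has the second highest of the three numbers, and every step among these compounds lies within the scatter, so no ordering among them can be claimed.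

Compound 4 `CCOc1ccc(Nc2c(C(=O)c3cc(OC)c(OC)c(OC)c3)sc3ccccc23)cc1` is not yet measured. It differs from compound 3 by (4-ethoxyphenyl)amino in place of 4-ethoxyphenyl on an aromatic carbon. Among the measured compounds shown here, none of the measured steps concerns such a change: all three alter only the substituent on the pendant ring, and all were within the scatter. For the measured compounds named here, the data therefore give no direction for this step, and compound 4 is expected to land near compound 3, with no change at the digits printed from compound 3 to compound 4 (within the scatter) expected to stay within the scatter but with wide uncertainty. Compound 4 is estimated at 3000 nM, in a range from 800 nM to 12000 nM.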

Compound 4, half-maximal inhibitory concentration: 700 nM
Estimate against measurement, compound 4: 4.3-fold (0.63 log units) above; measured number below the stated range.
By their numbers in this assay, from the lowest: compound 4; then compounds 1, 3 and 2 (each within the scatter of the next).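

Replacing 4-ethoxyphenyl with (4-ethoxyphenyl)amino on this aromatic carbon of the five-membered ring gives a step beyond the scatter in this assay, a 4.3-fold lower number from compound 3 to compound 4 (0.63 log units; beyond the scatter), whereas the substituent changes on the pendant ring among compound 1, compound 2 and compound 3 all stayed within it. The other two steps, a 5.0-fold lower number from compound 2 to compound 4 (0.70 log units; beyond the scatter) and a 2.7-fold lower number from compound 1 to compound 4 (0.43 log units; beyond the scatter), also lie beyond the scatter, so among these four compounds, compound 4 alone stands apart and this position responds to the amino link. No available evidence bears on why this change lowers the number.

The compounds shown leave open whether the amine hydrogen is needed, or whether a methylamino link, an ether oxygen or a methylene link would serve as well. They also leave open how the number responds to other pendant-ring substituents, such as methylsulfanyl, once the amino link is present.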